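The source may report more compounds than this note shows. Statements on the series, on what has been measured and on what is new or still open speak of the compounds shown alone.

Measured compounds:
compound 1 `CCOC(=O)CCCCCOc1cccc(CN(C(=O)c2ccc(-c3cccc(NC(C)=O)c3)cc2)C(C)C)c1` — > 26000 nM
compound 2 `CCOC(=O)CCCCCOc1cccc(CN(C(=O)c2ccc(-c3cccc(C(C)=O)c3)cc2)C(C)C)c1` — > 26000 nM
compound 3 `CCOC(=O)CCCCCOc1cccc(CN(C(=O)c2ccc(-c3cccc(OCC(C)C)c3)cc2)C(C)C)c1` — > 26000 nM

In an ADME assay on Raji cells (Homo sapiens) for cytotoxicity, read by CellTiter-Glo and resazurin assay, with a stated time of 72 h (a lower number here means that less compound is needed, a higher number that more compound is needed for the effect), compound 1 gives > 26000 nM, which is a limit of the assay and not a number. Compound 2 gives > 26000 nM, likewise a limit. Compound 3 gives > 26000 nM, also a limit. All three values therefore sit at the limit of > 26000 nM in this assay, at which 3 of the 3 values shown sit, and compound 3 stands nowhere in particular among them: no value shown separates it from the others.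

The measured steps are a step that the two limits leave unreadable from compound 1 to compound 2, a step that the two limits leave unreadable from compound 1 to compound 3 and a step that the two limits leave unreadable from compound 2 to compound 3. Each exchanges the group on the aromatic carbon, and each is unreadable, since both ends are limits.

Compound 4 `CCOC(=O)CCCCCOc1cccc(CN(C(=O)c2ccc(-c3cccc(OC)c3)cc2)C(C)C)c1` differs from compound 3 by hydrogen in place of isopropyl on a saturated chain carbon bound to an oxygen on an aromatic ring. Going by the values given here, no measured step touches this change directly; the three unreadable steps only show that varying the group at this aromatic carbon, from acetamido through acetyl to isobutoxy, never brought any compound below the limit. With no readable step to build on, the step from compound 3 to compound 4 is expected to be small or none, a step that the limit leaves unreadable from compound 3 to compound 4, and most likely compound 4 will again return only a limit.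

Compound 4 is therefore estimated at 35000 nM in this assay, with a range from 15000 nM to 80000 nM.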

Compound 4, half-maximal effective concentration: > 21000 nM
Compound 4 gave a limit, no number; the forecaster's own chance of this, stated with the estimate: 85%; the middle value is on the limit's open side.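

In this assay compound 4 gives > 21000 nM, which is a limit of the assay and not a number. The steps to compound 4 from compound 1, compound 2 and compound 3 cannot be read, since both ends of each are limits. The compounds shown leave open at what concentration any of the four would reach a half-maximal effect in this assay, and how far apart they lie.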